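From Propoxy to Diethylamino on the Carbonyl Carbon

The source may report more compounds than this note shows. Statements on the series, on what has been measured and on what is new or still open speak of the compounds shown alone.

Compound 1 `CCOC(=O)c1ccc(/C=C/C(=O)c2cc(OC)ccc2OC)cc1` and compound 2 `CCCOC(=O)c1ccc(/C=C/C(=O)c2cc(OC)ccc2OC)cc1` share one core and were both tested in a functional assay on PC-3 cells (Homo sapiens) for cytotoxicity, read by MTT assay, with a stated time of 72 h; a higher number here means a weaker inhibitor, a lower number a stronger inhibitor. Compound 1 gives 5700 nM, while compound 2 gives 26900 nM, the higher of the two numbers, separated by a 4.7-fold higher number from compound 1 to compound 2 (0.67 log units; beyond the scatter). Compound 3 `CCN(CC)C(=O)c1ccc(/C=C/C(=O)c2cc(OC)ccc2OC)cc1` differs from compound 2 in a single place: diethylamino in place of propoxy on a carbonyl carbon. Going by the values given here, no measured step involves this kind of exchange; the only step seen, a 4.7-fold higher number from compound 1 to compound 2 (0.67 log units; beyond the scatter), concerns a different change, so no particular direction can be expected beyond the scatter. Compound 3 is therefore estimated at 15000 nM, within 4000 nM to 50000 nM, which means an expected step of a 1.8-fold lower number from compound 2 to compound 3 (0.25 log units; within the scatter).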

Compound 3, half-maximal inhibitory concentration: 3790 nM
Beside the measured number, compound 3's estimate is 4.0-fold (0.60 log units) above it; the measured number lies below the stated range.
By their numbers in this assay, from the lowest: compounds 3 and 1 (each within the scatter of the next); then compound 2.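

Exchanging propoxy for diethylamino on the carbonyl carbon gives a 7.1-fold lower number from compound 2 to compound 3 (0.85 log units; beyond the scatter), so the rise seen with the longer ester chain is not a fixed feature of this position. Against ethoxy, the same exchange gives a 1.5-fold lower number from compound 1 to compound 3 (0.18 log units; within the scatter), so here an amide and the shorter ester cannot be told apart. Nothing available explains why the numbers move this way.

From the compounds shown here alone, whether the nitrogen or its two ethyl groups matter more stays open. Dimethylamino, piperidine or a free carboxylic acid on this carbonyl carbon would test that.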